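A Longer Chain on a Flat Series

This account rests on a few compounds, and the source may have more. Where it says the series, first, only, none or still open, it means among the compounds named here.

In a functional assay on HL-60 cells (Homo sapiens) for cytotoxicity, read by WST assay, with a stated time of 48 h (on this read-out higher numbers stand for an effect only at larger amounts of compound and lower numbers for an effect already at smaller amounts), compound 1 (`O=C1OC[C@H](Cc2ccccc2)[C@H]1Cc1ccccc1`) gives 77000 nM and compound 2 (`COc1ccc(C[C@H]2C(=O)OC[C@@H]2Cc2ccccc2)cc1`) gives 67000 nM while compound 3 (`COCOc1ccc(C[C@H]2C(=O)OC[C@@H]2Cc2ccccc2)cc1`) gives 71000 nM so compound 3 stands level with both, within the scatter. Compound 4 (`CCCCCCCOc1ccc(C[C@H]2C(=O)OC[C@@H]2Cc2ccccc2)cc1`) carries hexyl in place of methoxy on a saturated chain carbon bound to an oxygen on an aromatic ring. The measured steps that bear on this are small: a 1.1-fold lower number from compound 1 to compound 2 (0.06 log units; within the scatter) and a 1.1-fold lower number from compound 1 to compound 3 (0.04 log units; within the scatter) and a 1.1-fold higher number from compound 2 to compound 3 (0.03 log units; within the scatter) all lie within the scatter. Among the measured compounds shown here, no measured compound carries a chain this long, so these steps guide only loosely. The expected step is a 1.8-fold lower number from compound 3 to compound 4 (0.25 log units; within the scatter) and so no large change is foreseen. For compound 4 the estimate is 40000 nM with an expected range from 12000 nM to 90000 nM as the likely span.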

Compound 4, half-maximal effective concentration: > 100000 nM
Compound 4: a limit, no number; the forecaster's own chance of this, stated with the estimate: 15%; middle value at least 2.5-fold (0.39 log units) away from the limit.
By their numbers in this assay, from the lowest: compounds 2, 3 and 1 (each within the scatter of the next). At a limit, above all of these: compound 4.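

Compound 4 gives a limit, not a number: the limit of > 100000 nM in this assay, at which 1 of the 4 values shown sits. Read against the others, that limit gives an at least 1.4-fold higher number from compound 3 to compound 4 (0.14 log units; that floor lies within the scatter), as well as an at least 1.4-fold higher number from compound 2 to compound 4 (0.17 log units; that floor lies within the scatter) and an at least 1.2-fold higher number from compound 1 to compound 4 (0.11 log units; that floor lies within the scatter). Methoxy and methoxymethoxy left the numbers level, whereas hexyl at this place gives no measured number at all, and since each floor lies within the scatter, the true size of the change remains unknown.

Going by these compounds, whether a shorter chain such as propyl, or an amine or a carboxylic acid at the end of the hexyl chain, would give a measurable number stays open.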